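The source may hold more compounds than are shown below. What is called first, only, known or untested is meant among the compounds shown, and "the series" means these compounds.

Compound 1 `Cc1ccc(C(=O)Nc2cccc(-c3oc4cc(-c5ccc(F)cc5)ccc4c(=O)c3O)c2)cc1` and compound 2 `COc1ccccc1C(=O)Nc1cccc(-c2oc3cc(-c4ccc(F)cc4)ccc3c(=O)c2O)c1` share one core and differ only in the ring attached to the carbonyl. In a functional assay on MCF7 cells (Homo sapiens) for antiproliferative activity, read by CCK-8 assay, with a stated time of 72 h (on this read-out higher numbers stand for weaker inhibition and lower numbers for stronger inhibition), compound 1 gives 2400 nM, and compound 2 gives 2100 nM. The step of a 1.1-fold lower number from compound 1 to compound 2 (0.06 log units; within the scatter) lies within the scatter, so the two stand level. Compound 3 `O=C(Nc1cccc(-c2oc3cc(-c4ccc(F)cc4)ccc3c(=O)c2O)c1)c1ccc(C(F)(F)F)cc1` carries the change (4-(trifluoromethyl)phenyl in place of 2-methoxyphenyl on a carbonyl carbon). Among the measured compounds shown here, the one comparable step, a 1.1-fold lower number from compound 1 to compound 2 (0.06 log units; within the scatter), was small, so swapping the aryl ring on the carbonyl has moved little so far. No step beyond the scatter is expected, a 1.0-fold higher number from compound 2 to compound 3 (0.02 log units; within the scatter). The estimate for compound 3 in this assay is 2200 nM, between 1000 nM and 5000 nM.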

Compound 3, half-maximal inhibitory concentration: 32600 nM
Beside the measured number, compound 3's estimate is 15-fold (1.17 log units) below it; the whole stated range lies below it.
By their numbers in this assay, from the lowest: compounds 2 and 1 (each within the scatter of the next); then compound 3.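

Among the compounds shown here, the ring on this carbonyl is not as free to change as the first pair of compounds suggested: in this assay, a 16-fold higher number from compound 2 to compound 3 (1.19 log units; beyond the scatter) accompanies the arrival of 4-(trifluoromethyl)phenyl. The sharper comparison is a 14-fold higher number from compound 1 to compound 3 (1.13 log units; beyond the scatter) for trifluoromethyl in place of methyl on an aromatic carbon, a change in one group alone that weakens inhibition. No measurement here accounts for this loss. Still open, on these data alone, is whether a chlorine atom, an amine or a carboxylic acid in place of that trifluoromethyl would stay level with compound 1 or fall as far as compound 3.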